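The source may report more compounds than this note shows. Statements on the series, on what has been measured and on what is new or still open speak of the compounds shown alone.

The study concerns antagonism of the D(4) dopamine receptor, followed in an assay on cells for antagonist activity at D(4) dopamine receptor (Homo sapiens), read by luminescence and beta-arrestin recruitment, with a stated time of 90 min; on this read-out lower numbers stand for stronger inhibition and higher numbers for weaker inhibition. Compound 1 `Cc1cccc(NC(=O)CN2CCC(c3ccccc3)CC2)c1` gives 135 nM in this assay, the lowest of the two numbers recorded. Compound 2 `Cc1cccc(NC(=O)CCN2CCN(c3ncccn3)CC2)c1` gives 430 nM, a gap from compound 1 that lies beyond the usual scatter, while compound 3 `O=C(CN1CCN(c2ccccn2)CC1)Nc1cncnc1` is reported in this assay as "not active" (no number reported) with no number attached. For the measured compounds named here, no two measured compounds differ in a single place, so there is no measured step to lean on. Compound 4 `Cc1ccc(C2CCN(CC(=O)Nc3cccc(C)c3)CC2)nc1` is the untested partner of compound 1; the change between them is 5-methylpyridin-2-yl in place of phenyl on a saturated ring carbon. Going by the values given here, with no single-point steps to draw on, the size of this step is open; a modest move toward weaker inhibition, close to the edge of the scatter, is expected, the expected step from compound 1 to compound 4 being a 1.9-fold higher number from compound 1 to compound 4 (0.27 log units; within the scatter). Compound 4 is therefore estimated at 250 nM in this assay, with a likely range from 60 nM to 1000 nM.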

Compound 4, half-maximal inhibitory concentration: 394 nM
Compound 4: the middle estimate sits 1.6-fold (0.20 log units) below what was measured; the range from low to high includes it.
By their numbers in this assay, from the lowest: compound 1; then compounds 4 and 2 (each within the scatter of the next).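

In this assay, for the compounds shown here, the exchange of phenyl for 5-methylpyridin-2-yl gives the first single-place step, a 2.9-fold higher number from compound 1 to compound 4 (0.47 log units; beyond the scatter) and beyond the scatter, which shows that the number responds to what is carried on this saturated ring carbon. The step is modest, and compound 4 still gives a number, so an aromatic ring with a hetero atom at this place does not abolish inhibition. Nothing measured here accounts for the size or direction of the step.

The ring nitrogen and the methyl enter together in this pair, and the compounds shown do not tell their contributions apart, as an unsubstituted pyridin-2-yl group at the same place might. On these data alone, how a saturated ring such as cyclohexyl, or an amine or carboxylic acid on the aromatic ring, would fare here also remains open.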